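Replacing the chloroacetyl group of compound 2 with a pentylurea

This account rests on a few compounds, and the source may have more. Where it says the series, first, only, none or still open, it means among the compounds named here.

Compound 2 `CC(C)c1ccccc1OS(=O)(=O)c1ccc(NC(=O)CCl)cc1` stands level with compound 3 `O=C(CCl)Nc1ccc(S(=O)(=O)Oc2ccccc2I)cc1` in a functional assay on M21 cells (Homo sapiens) for antiproliferative activity, read by sulforhodamine B assay, with a stated time of 48 h (on this read-out lower numbers stand for stronger inhibition and higher numbers for weaker inhibition), where compound 2 gives 3900 nM and compound 3 gives 3900 nM, while compound 1 `CCCCCC(=O)Nc1ccc(S(=O)(=O)Oc2ccccc2I)cc1` gives 11000 nM. The step of no change at the digits printed from compound 2 to compound 3 (within the scatter) shows that the aryl ester substituent can be swapped without consequence, whereas the step of a 2.8-fold lower number from compound 1 to compound 3 (0.45 log units; beyond the scatter) shows that a saturated chain in place of the chloro on the carbon attached to the carbonyl carries a cost. Compound 4 `CCCCCNC(=O)Nc1ccc(S(=O)(=O)Oc2ccccc2C(C)C)cc1` differs from compound 2 by pentylamino in place of chloromethyl on a carbonyl carbon, which removes that chloro and installs a longer chain, so a rise in the number in this assay is expected, of a size like a 2.8-fold higher number from compound 2 to compound 4 (0.45 log units; beyond the scatter). Compound 4 is therefore estimated at 11000 nM, with a range from 4000 nM to 30000 nM.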

Compound 4, half-maximal inhibitory concentration: 4600 nM
For compound 4 the middle estimate is 2.4-fold (0.38 log units) above the measured one, within the range that was stated.
By their numbers in this assay, from the lowest: compounds 2, 3 and 4 (each within the scatter of the next); then compound 1.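

In this assay the change on this carbonyl carbon gives a 1.2-fold higher number from compound 2 to compound 4 (0.07 log units; within the scatter) and so pentylamino stands in place of chloromethyl without a cost that can be read. The chloro is thus not needed for this level in compound 4, although chloro and butyl differ in a 2.8-fold lower number from compound 1 to compound 3 (0.45 log units; beyond the scatter) on the saturated chain carbon. No measured evidence bears on this result. The compounds shown leave open whether a shorter chain, a longer chain or a terminal amine would hold this level, and whether pentylamino behaves alike with iodo in place of isopropyl on the aromatic carbon.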